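This account rests on a few compounds, and the source may have more. Where it says the series, first, only, none or still open, it means among the compounds named here.

Three compounds share one core and differ only in the group on the aromatic ring. Compound 1 `Nc1ccc2c(c1)C1CNCC2C1` gives 100 nM in an assay on HEK293 cells for binding affinity to Neuronal acetylcholine receptor; alpha4/beta2 (Homo sapiens); a higher number here means a weaker inhibitor, a lower number a stronger inhibitor. Compound 2 `CC(=O)Nc1ccc2c(c1)C1CNCC2C1` gives 75 nM in this assay, and the step of a 1.3-fold lower number from compound 1 to compound 2 (0.12 log units; within the scatter) lies within the scatter. Compound 3 `O=S(=O)(c1ccc2c(c1)C1CNCC2C1)N1CC1` gives 2 nM in this assay and stands lowest of the three numbers, both of its neighbours being far above it.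

Compound 4 `FC(F)(F)c1ccc2c(c1)C1CNCC2C1` is not yet measured. Its change from compound 3 is a group of 4 heavy atoms (1 carbon, 3 fluorine; no ring) in place of a group of 6 heavy atoms (2 carbon, 1 nitrogen, 2 oxygen, 1 sulfur; one three-membered non-aromatic ring with 1 hetero atom), on an aromatic carbon: the entering trifluoromethyl has no ring and no hydrogen-bond acceptors, whereas the leaving group carries two.

For the measured compounds named here, two measured steps bear on this change. The step of a 50-fold lower number from compound 1 to compound 3 (1.70 log units; beyond the scatter) and the step of a 38-fold lower number from compound 2 to compound 3 (1.57 log units; beyond the scatter) both show that putting this six-atom group onto the aromatic carbon, in place of a small group, brought a large drop in the number. Taking the group away again is expected to undo much of that gain, so the estimated step of a 25-fold higher number from compound 3 to compound 4 (1.40 log units; beyond the scatter) points upward and beyond the scatter. Going by the values given here, no measured compound carries trifluoromethyl, so the size is uncertain. Compound 4 is expected to give about 50 nM in this assay, within a range of 10 nM to 300 nM.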

Compound 4, inhibition constant: 0.33 nM
Compound 4: the middle estimate sits 150-fold (2.18 log units) above what was measured; the whole stated range lies above it.
By their numbers in this assay, from the lowest: compound 4; then compound 3; then compounds 2 and 1 (each within the scatter of the next).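

The earlier compounds shown here could suggest that the six-atom group of compound 3, with its three-membered ring and 2 hydrogen-bond acceptors, was what brought the number down, yet in this assay the step of a 6.1-fold lower number from compound 3 to compound 4 (0.78 log units; beyond the scatter) shows that trifluoromethyl, with no ring and 0 hydrogen-bond acceptors, goes lower still. At this aromatic carbon, then, neither that ring nor those acceptors are needed for a low number, and the steps of a 230-fold lower number from compound 2 to compound 4 (2.36 log units; beyond the scatter) and a 300-fold lower number from compound 1 to compound 4 (2.48 log units; beyond the scatter) set trifluoromethyl far apart from both acetamido and amino, the two groups here joined to the ring through nitrogen. No measurement is at hand that explains this order among the four groups.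

As far as these compounds go, whether trifluoromethyl is unusual at this carbon, or whether other small groups such as a methyl, a nitrile, a methoxy or a single chlorine atom would give equally low numbers, remains open. Also open, from the compounds shown here alone, is what a carboxylic acid or a longer chain would do here, and how much of the low number of compound 4 would remain with a plain hydrogen in this place.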